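Chloro for methyl on the core of compound 2

The source may hold more compounds than are shown below. What is called first, only, known or untested is meant among the compounds shown, and "the series" means these compounds.

Of the compounds shown here, two have been measured in a functional assay for positive allosteric modulation of GABA-B receptor (Homo sapiens), read by GTPgammaS binding; on this read-out higher numbers stand for an effect only at larger amounts of compound and lower numbers for an effect already at smaller amounts. Compound 1 `Cc1nc(N[C@@H]2C[C@H]3CC[C@@H]2C3)c2cc(-c3cccc(Cl)c3)ccc2n1` gives 199 nM in this assay. Compound 2 `Cc1nc(N[C@@H]2C[C@H]3CC[C@@H]2C3)c2cc(-c3cccc(C(F)(F)F)c3)ccc2n1` gives 142 nM in this assay, and the single measured step, a 1.4-fold lower number from compound 1 to compound 2 (0.15 log units; within the scatter), stays within the scatter, so compound 2 and compound 1 cannot be told apart on the numbers shown. Compound 3 `FC(F)(F)c1cccc(-c2ccc3nc(Cl)nc(N[C@@H]4C[C@H]5CC[C@@H]4C5)c3c2)c1` has not been measured; it differs from compound 2 by chloro in place of methyl on an aromatic carbon. Among the compounds with values here, no measured step touches this exchange: the only step recorded so far swapped groups on an aromatic carbon elsewhere in the molecule and stayed within the scatter, so it gives no direction for the present change. No shift beyond the scatter is therefore expected, and the expected step is a 1.1-fold higher number from compound 2 to compound 3 (0.02 log units; within the scatter). For compound 3 the estimated value in this assay is 150 nM, with a range from 50 nM to 450 nM.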

Compound 3, half-maximal effective concentration: 90 nM
Beside the measured number, compound 3's estimate is 1.7-fold (0.22 log units) above it; the measured number falls inside the stated range.
By their numbers in this assay, from the lowest: compounds 3, 2 and 1 (each within the scatter of the next, the first and the last beyond it).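

The position between two ring nitrogen atoms now has its first reading: in this assay, chloro in place of methyl gives a 1.6-fold lower number from compound 2 to compound 3 (0.20 log units; within the scatter). On the numbers shown, methyl on this aromatic carbon can therefore be exchanged for chloro without a shift beyond the scatter, whereas the earlier step spoke only to a different place on the molecule. Nothing shown gives a reason for this result.

Whether this position also tolerates a larger or very different group, such as an amine, a methoxy group or a nitrile, remains open, since the compounds shown carry only methyl and chloro here. Also open, on these data alone, is whether the same exchange would read alike on compound 1, which carries chloro where compound 2 carries trifluoromethyl.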